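From Pentyl to Phenyl on a Shared Ether Oxygen

The compounds below may be only part of what the source reports. "The series", "measured", "known", "first", "only" and "open" are said of these compounds alone.

Three measured compounds share one core and differ only in the saturated chain on the oxygen on the aromatic ring:

In a functional assay on BGC-823 cells (Homo sapiens) for cytotoxicity, read by MTT assay, with a stated time of 48 h (on this read-out lower numbers stand for stronger inhibition and higher numbers for weaker inhibition), compound 1 `CC(C)COc1ccc2c(Cl)ccnc2c1` gives 3030 nM.
In this assay compound 2 `CCCCOc1ccc2c(Cl)ccnc2c1` gives 3610 nM.
In this assay compound 3 `CCCCCCOc1ccc2c(Cl)ccnc2c1` gives 2380 nM.

Compound 3 holds the lowest of the three numbers, yet neither neighbour is separated from it by more than the scatter: a 1.3-fold lower number from compound 1 to compound 3 (0.10 log units; within the scatter) and a 1.5-fold lower number from compound 2 to compound 3 (0.18 log units; within the scatter) are both small, as is a 1.2-fold higher number from compound 1 to compound 2 (0.08 log units; within the scatter). The three alkyl variants therefore read as one group with no resolved order, and compound 3 cannot be called the most potent of them.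

Compound 4 `Clc1ccnc2cc(OCc3ccccc3)ccc12` takes the next step: phenyl in place of pentyl on a saturated chain carbon bound to an oxygen on an aromatic ring. Going by the values given here, no measured step replaces a chain with a ring; the three steps that exist only change the shape or length of an alkyl chain, and each stayed within the scatter. There is thus no measured basis for a shift in either direction in this assay, and the expectation for compound 4 is a number close to that of compound 3, a step of a 1.1-fold higher number from compound 3 to compound 4 (0.02 log units; within the scatter) that is not expected to exceed the scatter. Compound 4 is estimated at 2500 nM, with a plausible range from 900 nM to 7000 nM.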

Compound 4, half-maximal inhibitory concentration: 5170 nM
The estimate for compound 4 lay 2.1-fold (0.32 log units) below the measured number, and the stated range covers the measured number.
By their numbers in this assay, from the lowest: compounds 3, 1, 2 and 4 (each within the scatter of the next, the first and the last beyond it).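

In this assay, going by these compounds alone, phenyl in place of pentyl on a saturated chain carbon bound to an oxygen on an aromatic ring gives the first step at this position that lies beyond the scatter (a 2.2-fold higher number from compound 3 to compound 4 (0.34 log units; beyond the scatter)), though a modest one, whereas every step among the three alkyl variants stayed within it. The separation holds only against compound 3, since the steps from the other two chains remain within the scatter (a 1.4-fold higher number from compound 2 to compound 4 (0.16 log units; within the scatter) and a 1.7-fold higher number from compound 1 to compound 4 (0.23 log units; within the scatter)), so the ring does not set compound 4 apart from the alkyl group as a whole. Nothing in the information available accounts for the step from pentyl to phenyl.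

The compounds shown leave open whether a saturated cyclohexyl ring on the same carbon would read with compound 3 or with compound 4, which would help to tell whether an aromatic ring matters here or a ring of any kind. They also leave open how a chain longer than that of compound 3, or one ending in an amine or a carboxylic acid, would read in this assay.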